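The source may hold more compounds than are shown below. What is called first, only, known or untested is meant among the compounds shown, and "the series" means these compounds.

Compound 1 `COc1cc(O)c([C@@H]2CC(=O)c3c(O)cc(O)cc3O2)cc1C/C=C(\C)CCC=C(C)C`, in a functional assay on U-266 cells (Homo sapiens) for cytotoxicity, with a stated time of 72 h (on this read-out lower numbers stand for an effect already at smaller amounts and higher numbers for an effect only at larger amounts of compound), compound 1 gives > 10000 nM, a limit of the assay and not a number.
Compound 2 `C=C(C)C(O)CC/C(C)=C/Cc1c(O)cc2c(c1O)C(=O)C[C@@H](c1ccc(O)c(OC)c1)O2`, in this assay compound 2 gives > 10000 nM, again only a limit.

Compound 2 thus stands where every value shown stands, namely at the limit of > 10000 nM in this assay, at which 2 of the 2 values shown sit. Among the measured compounds shown here, no step between two measured compounds is available, so no measured size of change guides the next pair.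

Compound 3 `COc1cc([C@@H]2CC(=O)c3c(cc(O)c(C/C=C(\C)C/C=C/C(C)(C)O)c3O)O2)ccc1O` is the untested member. It differs from compound 2 by 3-hydroxy-3-methylbut-1-en-1-yl in place of 2-hydroxy-3-methylbut-3-en-1-yl on a saturated chain carbon bound to a double-bonded chain carbon. A shift of the hydroxyl within the same chain is not expected to move the read-out beyond the usual scatter, and the expected step from compound 2 to compound 3 in this assay is a step that the limit leaves unreadable from compound 2 to compound 3. Compound 3 is estimated at 20000 nM, within 8000 nM to 50000 nM, most likely reported only as a limit.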

Compound 3, half-maximal effective concentration: > 10000 nM
Compound 3 ended at the assay's limit; the forecaster's own chance of this, stated with the estimate: 80%; the middle value is on the limit's open side.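

No step can be read between compound 2 and compound 3, since both values are limits and not numbers: the limit of > 10000 nM in this assay, at which 3 of the 3 values shown sit.

The compounds shown leave open whether any member of the series gives a readable value in this assay, and how large a value that would be.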